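This account rests on a few compounds, and the source may have more. Where it says the series, first, only, none or still open, it means among the compounds named here.

Compound 1 `O=C(OC1CCC1)c1cccc(=O)[nH]1` gives 62000 nM in an assay on isolated protein for inhibition of matrix metalloproteinase-9 (Homo sapiens); a higher number here means a weaker inhibitor, a lower number a stronger inhibitor.
Compound 2 `COc1ccc(COC(=O)c2cccc(=O)[nH]2)cc1` gives 100000 nM in this assay.

Both compounds share a core carrying an ester, and both are weak inhibitors in this assay. Compound 2 and compound 1 give numbers that lie within the usual scatter of each other, so nothing separates them with confidence.

Compound 3 `Cc1ccc(COC(=O)c2cccc(=O)[nH]2)cc1` has not yet been measured. It differs from compound 2 in one place: methyl in place of methoxy on an aromatic carbon. Among the measured compounds shown here, no measured pair yet shows what such a swap does on this core, so there is no step to lean on. With compound 2 at 100000 nM and compound 1 at 62000 nM both sitting at the weak end, the small change is expected to move the number little, if at all beyond the scatter, in either direction. For compound 3 the expected value in this assay is 90000 nM, within a range of 30000 nM to 300000 nM, which is the step of a 1.1-fold lower number from compound 2 to compound 3 (0.05 log units; within the scatter).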

Compound 3, half-maximal inhibitory concentration: 68000 nM
Compound 3: middle estimate off by 1.3-fold (0.12 log units), on the high side; the range from low to high includes it.
By their numbers in this assay, from the lowest: compounds 1, 3 and 2 (each within the scatter of the next).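

Among the compounds shown here, this is the first pair on the shared core that differs in one place, and in this assay the swap of methoxy for methyl gives a 1.5-fold lower number from compound 2 to compound 3 (0.17 log units; within the scatter) and so stays within the usual scatter. At this position, on the aromatic carbon para to a large group, removing the oxygen of the methoxy group therefore does not separate the two compounds with confidence. Nothing shown here offers a reason for this result or tells what either group does at this position.

As far as these compounds go, it remains open whether another group at this position, such as an amine, a carboxylic acid or a longer chain, would move the number beyond the scatter. From the compounds shown here alone, it is equally open whether an amide in place of the ester on the shared core would do so.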